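This account rests on a few compounds, and the source may have more. Where it says the series, first, only, none or still open, it means among the compounds named here.

In a functional assay on MCF7 cells (Homo sapiens) for antiproliferative activity, read by MTT assay, with a stated time of 24 h (on this read-out higher numbers stand for weaker inhibition and lower numbers for stronger inhibition), compound 1 `CCn1c(C(=O)N[C@@H](C)C(=O)OC)ccc1C(CC)(CC)c1ccc(OCS(=O)(=O)c2ccccc2)c(C)c1` gives 43700 nM and compound 3 `CCn1c(C(=O)N[C@H](CO)CCO)ccc1C(CC)(CC)c1ccc(OCS(=O)(=O)c2ccccc2)c(C)c1` gives 28500 nM, two values within the scatter of each other. Compound 2 `CCn1c(C(=O)N[C@@H](CC(=O)OC)C(=O)OC)ccc1C(CC)(CC)c1ccc(OCS(=O)(=O)c2ccccc2)c(C)c1` returns only a limit, > 50000 nM. Compound 4 `CCn1c(C(=O)N[C@H](C(=O)O)C(C)C)ccc1C(CC)(CC)c1ccc(OCS(=O)(=O)c2ccccc2)c(C)c1` keeps the shared core and alters only the group on the amide-type nitrogen: 1-carboxy-2-methylpropyl in place of 3-hydroxy-1-(hydroxymethyl)propyl on an amide-type nitrogen. For the measured compounds named here, three measured steps bear on this place: a 1.5-fold lower number from compound 1 to compound 3 (0.19 log units; within the scatter), an at least 1.7-fold lower number from compound 2 to compound 3 (0.24 log units; that floor lies within the scatter) and an at least 1.1-fold higher number from compound 1 to compound 2 (0.05 log units; that floor lies within the scatter). None of them is shown beyond the scatter, although the two involving compound 2 rest on a limit. No step beyond the scatter is therefore expected in this assay. The expected change is a 1.3-fold higher number from compound 3 to compound 4 (0.12 log units; within the scatter). For compound 4 the estimated value is 38000 nM, with an expected range of 18000 nM to 50000 nM.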

Compound 4, half-maximal inhibitory concentration: 24500 nM
Compound 4: the middle estimate sits 1.6-fold (0.19 log units) above what was measured, within the range that was stated.
By their numbers in this assay, from the lowest: compounds 4, 3 and 1 (each within the scatter of the next). At a limit, above all of these: compound 2.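

Placing 1-carboxy-2-methylpropyl on the amide-type nitrogen brings a free carboxy group to this position, yet the number stays within the scatter of both the hydroxyl-bearing and the ester-bearing groups (a 1.2-fold lower number from compound 3 to compound 4 (0.07 log units; within the scatter)) and (a 1.8-fold lower number from compound 1 to compound 4 (0.25 log units; within the scatter)). Hydroxyl, methyl ester and carboxy groups here therefore give no measured separation across compounds 1, 3 and 4. The remaining step rests on a limit and gives only a floor (an at least 2.0-fold lower number from compound 2 to compound 4 (0.30 log units; that floor lies within the scatter)): the limit of > 50000 nM in this assay, at which 1 of the 4 values shown sits.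

As far as these compounds go, whether an amine or a much longer chain on this nitrogen would move the number beyond the scatter stays open. So does how the methyl ester of the 1-carboxy-2-methylpropyl group would compare.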